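The source may hold more compounds than are shown below. What is called first, only, known or untested is meant among the compounds shown, and "the series" means these compounds.

Measured compounds:
compound 1 `Nc1ccccc1NC(=O)CCCNCC(=O)Nc1cccc(Cl)c1` gives 19500 nM
compound 2 `Nc1ccccc1NC(=O)CCCNCC(=O)Nc1cc(Cl)ccc1Cl` gives 44000 nM

Both numbers come from a functional assay on U-251 cells (Homo sapiens) for inhibition, read by MTT assay, with a stated time of 2 days; on this read-out higher numbers stand for weaker inhibition of growth and lower numbers for stronger inhibition of growth. Compound 1 stands lowest of the two values; its nearest neighbour is compound 2, and the step of a 2.3-fold higher number from compound 1 to compound 2 (0.35 log units; beyond the scatter) is a modest one, beyond the scatter, and corresponds to chloro in place of hydrogen on an aromatic carbon.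

The next compound, compound 3 `Nc1ccccc1NC(=O)CCCNCC(=O)Nc1ccccc1Cl`, has not yet been measured in this assay. It differs from compound 1 only in the arrangement of the same atoms: 2-chlorophenyl in place of 3-chlorophenyl on an amide-type nitrogen. Going by the values given here, no measured pair shows exactly this change. Among the compounds with values here, the only step that bears on it is the one from compound 1 to compound 2, where a second chlorine on that phenyl ring weakened growth inhibition by a modest amount; compound 3 also carries a 2-chlorophenyl group, as compound 2 does, but lacks the chlorine that compound 1 carries. The direction is therefore uncertain, and a step of a 1.5-fold higher number from compound 1 to compound 3 (0.19 log units; within the scatter) is expected, most likely toward a weaker number, but not far beyond the scatter. For compound 3 the estimate in this assay is 30000 nM, within a range from 12000 nM to 75000 nM.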

Compound 3, concentration for 50% growth inhibition: 28600 nM
Compound 3: the middle estimate sits 1.0-fold (0.02 log units) above what was measured; low and high end bracket the measured number.
By their numbers in this assay, from the lowest: compounds 1, 3 and 2 (each within the scatter of the next, the first and the last beyond it).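

In this assay, the new pair tests where the chlorine sits on the ring: 2-chlorophenyl in place of 3-chlorophenyl on an amide-type nitrogen gives a difference within the scatter (a 1.5-fold higher number from compound 1 to compound 3 (0.17 log units; within the scatter)), so this assay does not separate the two arrangements. Compound 3 also shows that the chlorine step depends on the compound it is read from: hydrogen in place of chloro on an aromatic carbon stays within the scatter (a 1.5-fold lower number from compound 2 to compound 3 (0.19 log units; within the scatter)), whereas the earlier chlorine step lay beyond it (a 2.3-fold higher number from compound 1 to compound 2 (0.35 log units; beyond the scatter)), and only compounds 1 and 2 are separated from each other, with compound 3 close to both. No available evidence accounts for these small differences.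

The compounds shown leave open how an unsubstituted phenyl, or a phenyl carrying fluoro or methoxy in place of chloro, would compare on that amide-type nitrogen. They also leave open whether a longer chain between the amine and the anilide carbonyl would change the numbers in this assay by more than these ring changes do.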